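Aryl Ether in Place of a Branched Alkyl on the Core

The source may report more compounds than this note shows. Statements on the series, on what has been measured and on what is new or still open speak of the compounds shown alone.

Measured compounds:
compound 1, `COc1cccc(CNCCCNc2ccnc3cc(Oc4ccc(Cl)cc4)ccc23)c1O`: 9.28
compound 2, `COc1cccc(Oc2ccc3c(NCCCNCc4cc(F)ccc4OC)ccnc3c2)c1`: 9.28
compound 3, `CCC(CC)c1ccc2c(NCCCNCc3cccc(OC)c3O)ccnc2c1`: 9.47

In a physicochemical assay for acid dissociation, compound 3 gives the highest of the three numbers, yet its gaps to compound 1, the nearest, and to compound 2, the furthest, both lie within the scatter. Compound 4 `COc1cccc(Oc2ccc3c(NCCCNCc4cccc(OC)c4O)ccnc3c2)c1` differs from compound 3 by 3-methoxyphenoxy in place of pentan-3-yl on an aromatic carbon. Going by the values given here, the one measured step that bears on this change runs the opposite way: a number 0.19 log units higher from compound 1 to compound 3 (within the scatter), within the scatter. Compound 2, which carries the same 3-methoxyphenoxy group, gives a number equal to that of compound 1. Compound 4 is therefore expected to shift by a number 0.17 log units lower from compound 3 to compound 4 (within the scatter), nothing beyond the scatter. The estimate for compound 4 is 9.3, between 9.05 and 9.55.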

Compound 4, acid dissociation constant: 9.28
Compound 4: middle estimate off by 0.02 log units, on the high side; measured number inside the range.
By their numbers in this assay, from the lowest: compounds 1, 2, 4 and 3 (each within the scatter of the next).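

In this assay a ring-bearing aryl ether and a branched alkyl on this aromatic carbon give numbers within the scatter of each other (a number 0.19 log units lower from compound 3 to compound 4 (within the scatter)), now with the side chain held constant. The other two single changes also stay within the scatter: 2-hydroxy-3-methoxyphenyl in place of 5-fluoro-2-methoxyphenyl (no change at the digits printed from compound 2 to compound 4 (within the scatter)) and 3-methoxyphenyl in place of 4-chlorophenyl on the oxygen (no change at the digits printed from compound 1 to compound 4 (within the scatter)). No independent evidence is available to explain these results.

Going by these compounds, whether an amine or a carboxylic acid on this aromatic carbon would give a step beyond the scatter remains open.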